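The compounds below may be only part of what the source reports. "The series", "measured", "known", "first", "only" and "open" are said of these compounds alone.

Measured so far in the series:
Compound 1 `Nc1nc(O)c2ncn([C@H]3CCC[C@H]3CO)c2n1`: > 200000 nM
Compound 2 `Nc1nc(O)c2nnn([C@H]3CCC[C@H]3CO)c2n1`: 86700 nM
Compound 3 `Nc1nc(N)c2ncn([C@H]3CCC[C@H]3CO)c2n1`: 90000 nM

All three were run in a functional assay on CCRF-CEM cells (Homo sapiens) for antiproliferative activity; a higher number here means a weaker inhibitor, a lower number a stronger inhibitor. The value of compound 1 is a limit of the assay and not a number (the limit of > 200000 nM in this assay, at which 1 of the 3 values shown sits). Compound 3 gives 90000 nM in this assay. The change amino in place of hydroxy on an aromatic carbon gives an at least 2.2-fold lower number from compound 1 to compound 3 (0.34 log units; beyond the scatter), and this step is an at-least figure because the value of compound 1 is a limit (the limit of > 200000 nM in this assay, at which 1 of the 3 values shown sits).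

Compound 2 gives 86700 nM in this assay; its value and that of compound 3 lie within the scatter of each other. The difference between the core of compound 2 and the core of compound 1 is not broken down here.

Compound 4 `Nc1nc(N)c2nnn([C@H]3CCC[C@H]3CO)c2n1` has not been measured. It differs from compound 2 by amino in place of hydroxy on an aromatic carbon, the same change as from compound 1 to compound 3. The step expected from compound 2 to compound 4 in this assay is a 2.2-fold lower number from compound 2 to compound 4 (0.34 log units; beyond the scatter), beside the earlier one of an at least 2.2-fold lower number from compound 1 to compound 3 (0.34 log units; beyond the scatter); this rests on that single earlier step, which is itself only a floor. Compound 4 is therefore estimated at 40000 nM, expected to fall between 12000 nM and 130000 nM.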

Compound 4, half-maximal inhibitory concentration: 90500 nM
Estimate against measurement, compound 4: 2.3-fold (0.35 log units) below; measured number inside the range.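

In this assay, amino in place of hydroxy on an aromatic carbon gives a 1.0-fold higher number from compound 2 to compound 4 (0.02 log units; within the scatter), so on the core of compound 2 this change shows no step beyond the scatter. This does not show that the change behaves differently on the two cores, nor does it show that the change carries over from one core to the other: the same change on two cores in this assay, an at least 2.2-fold lower number (0.34 log units; beyond the scatter) from compound 1 to compound 3 and a 1.0-fold higher number (0.02 log units; within the scatter) from compound 2 to compound 4; the limit leaves it open whether they differ Compound 1 gives > 200000 nM, which is a limit of the assay and not a number.

Going by these compounds, what stays open is whether a true number for compound 1 would set the two steps apart, and so whether the effect of this change depends on the core at all. Also open is how a methoxy, chloro or methylamino group in place of the amino on that aromatic carbon would read on either core, as the compounds shown cover only amino and hydroxy there.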